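A few compounds are considered here, and "the series" means these few. Any claim that something is new, unique, unknown or untested is made for them only; others in the source may bear on it.

Compound 1 `CN1[C@@H]2c3[nH]c4ccccc4c3C[C@H]1[C@H](C#N)N1[C@@H](CNC(=O)c3cc4ccccc4s3)c3[nH]c4ccccc4c3C[C@@H]21`: 20 nM in a functional assay on A2780 cells (Homo sapiens) for cytotoxicity, read by MTT assay, with a stated time of 72 h; a lower number here means a stronger inhibitor, a higher number a weaker inhibitor. Compound 2 `CN1[C@@H]2c3[nH]c4ccccc4c3C[C@H]1[C@H](C#N)N1[C@@H](CNC(=O)c3cc4ccccc4[nH]3)c3[nH]c4ccccc4c3C[C@@H]21`: 7100 nM in this assay.

Among the measured compounds shown here, compound 2 holds the highest of the two numbers; the single measured step, a 360-fold higher number from compound 1 to compound 2 (2.55 log units; beyond the scatter), is large. Compound 3 `CN1[C@@H]2c3[nH]c4ccccc4c3C[C@H]1[C@H](C#N)N1[C@@H](CNC(=O)/C=C/c3cccc(C(F)(F)F)c3)c3[nH]c4ccccc4c3C[C@@H]21` differs from compound 2 in one place: 2-(3-(trifluoromethyl)phenyl)ethenyl in place of 1H-indol-2-yl on a carbonyl carbon. For the measured compounds named here, no measured step covers the entering group, so the estimate rests only on compound 2 giving the weaker number and on the step from compound 1 being large. The expected step is a 12-fold lower number from compound 2 to compound 3 (1.07 log units; beyond the scatter), toward a lower number, with wide uncertainty. Compound 3 is therefore estimated at 600 nM, between 60 nM and 6000 nM.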

Compound 3, half-maximal inhibitory concentration: > 10000 nM
Compound 3 gave a limit, no number; the forecaster's own chance of this, stated with the estimate: 5%; middle value at least 16-fold (1.22 log units) from the limit.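

Compound 3 stands at a limit of the assay, not a number: the limit of > 10000 nM in this assay, at which 1 of the 3 values shown sits.

The change reads as an at least 500-fold higher number from compound 1 to compound 3 (2.69 log units; beyond the scatter), so 1-benzothiophen-2-yl on this carbonyl carbon now stands apart from two different groups, not just 1H-indol-2-yl. Against the indole, the reading is an at least 1.4-fold higher number from compound 2 to compound 3 (0.14 log units; that floor lies within the scatter), which leaves the order of compound 2 and compound 3 unresolved.

Still open, as far as these compounds go, is whether the sulfur-containing ring itself matters, which 1-benzofuran-2-yl in this place would test. From the compounds shown here alone, how a simple amine or a carboxylic acid there would read in this assay also remains open.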